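Swapping Chloro for Trifluoromethoxy on a Shared Core

The source may report more compounds than this note shows. Statements on the series, on what has been measured and on what is new or still open speak of the compounds shown alone.

Three compounds were measured in a functional assay on HepG2 cells (Homo sapiens) for antiproliferative activity, read by CCK-8 assay, with a stated time of 72 h, tested at 8 uM; a higher number here means a stronger effect of the compound at the concentration tested, a lower number a weaker effect. Compound 1 `Nc1ccccc1NC(=O)/C=C/c1ccc(Cn2cnc3c(Nc4cccc(Cl)c4)nc(Cl)nc32)cc1` gives 49.3% in this assay. Compound 2 `CCC(C)n1cnc2c(NCc3ccc(C(=O)Nc4ccccc4N)cc3)nc(Cl)nc21` gives 65%, and compound 3 `CCCCn1cnc2c(Nc3ccccc3)nc(NCOCc3ccc(C(=O)Nc4ccccc4N)cc3)nc21` gives 70.7%. Compound 1 therefore stands lowest of the three, and each of the other two lies above it by more than the usual scatter of repeated measurements. The three compounds differ from one another in several places at once, so no single change can be traced between any two of them, and none of their comparisons speaks directly to the change examined here.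

Compound 4 `Nc1ccccc1NC(=O)/C=C/c1ccc(Cn2cnc3c(Nc4cccc(OC(F)(F)F)c4)nc(Cl)nc32)cc1` keeps the whole of compound 1 except for one group: trifluoromethoxy in place of chloro on an aromatic carbon. Within the data shown here, no measured pair shows what this exchange does, so the expectation rests on compound 1 alone. Compound 4 is expected to give about 52%, with a likely range from 35% to 70%. The step of a number 2.7 percentage points higher from compound 1 to compound 4 (within the scatter) is expected to be small, probably no larger than the scatter, with no clear direction.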

Compound 4, a percentage reported as inhibition, at one concentration (the size of the read-out at that concentration, not a potency): 37.6%
Estimate against measurement, compound 4: 14.4 percentage points above, within the range that was stated.
By their numbers in this assay, from the lowest: compound 4; then compound 1; then compounds 2 and 3 (each within the scatter of the next).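

In this assay, among these compounds, the change from 3-chlorophenyl to 3-(trifluoromethoxy)phenyl is the first single exchange that can be read on its own, and the read-out is a number 11.7 percentage points lower from compound 1 to compound 4 (beyond the scatter). Among the compounds shown here, the earlier compounds differed in several places at once, so only this pair shows that the group on this aromatic carbon matters to the read-out, and that here trifluoromethoxy does less well than chloro. No accompanying measurement bears on this step, so it stands as an observation without an explanation.

On these data alone, it remains open whether a methoxy group, a fluoro group or an amine on the same carbon would stay close to compound 1 or fall further. Also open, as far as these compounds go, is whether the same exchange would give a similar step with a butyl chain in place of the substituted benzyl group.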